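The source may hold more compounds than are shown below. What is called first, only, known or untested is meant among the compounds shown, and "the series" means these compounds.

Measured compounds:
compound 1, `CC(C)(C)OC(=O)N1CCC2(CC1)CC(CCCOc1ccc(S(C)(=O)=O)cc1F)C2`, 25 nM
compound 2, `CC(C)OC(=O)N1CCC2(CC1)CC(CCCOc1ccc(S(C)(=O)=O)cc1)C2`, 78 nM
compound 3, `CC(C)OC(=O)N1CCC2(CC1)CC(CCCOc1ccc(S(C)(=O)=O)c(F)c1)C2`, 18 nM

In a functional assay on cells for agonist activity at Glucose-dependent insulinotropic receptor (Homo sapiens), read by HTRF and cAMP accumulation, with a stated time of 30 min (a higher number here means that more compound is needed for the effect, a lower number that less compound is needed), compound 2 gives 78 nM, the highest number of the three. Compound 1 gives 25 nM, and compound 3 gives 18 nM; both gaps from compound 2 lie beyond the scatter. Compound 1 differs from compound 2 in two places, so its values alone cannot be read as a single step. Among the compounds with values here, the one single-point step available, a 4.3-fold lower number from compound 2 to compound 3 (0.64 log units; beyond the scatter), concerns a fluoro in place of hydrogen on an aromatic carbon and does not touch the carbamate.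

Compound 4, `CC(C)c1noc(N2CCC3(CC2)CC(CCCOc2ccc(S(C)(=O)=O)cc2)C3)n1`, is the unmeasured compound. It differs from compound 2 by 3-isopropyl-1,2,4-oxadiazol-5-yl in place of isopropoxycarbonyl on an amine nitrogen in a ring. Within the data shown here, no measured pair in this set changes the group on that ring nitrogen, so there is no step that bears directly on this replacement. The expectation for compound 4 therefore rests on compound 2 alone, and the estimated step is a 1.3-fold lower number from compound 2 to compound 4 (0.11 log units; within the scatter), with a range wide enough to allow either direction. Compound 4 is expected to give about 60 nM in this assay, between 15 nM and 250 nM.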

Compound 4, half-maximal effective concentration: 35 nM
Compound 4: the middle estimate sits 1.7-fold (0.23 log units) above what was measured; measured number inside the range.
By their numbers in this assay, from the lowest: compounds 3, 1 and 4 (each within the scatter of the next); then compound 2.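

In this assay, within the data shown here, the ring nitrogen of the shared core, so far seen only with carbamates, also carries a group without a carbonyl: 3-isopropyl-1,2,4-oxadiazol-5-yl in place of isopropoxycarbonyl gives a modest gain in the form of a 2.2-fold lower number from compound 2 to compound 4 (0.35 log units; beyond the scatter). The agonist activity therefore does not depend on the carbamate, at least in this one pair, and a five-membered aromatic ring with 3 hetero atoms can take its place on that nitrogen. Nothing measured alongside these numbers accounts for the gain, so the step stands only as a record of what was exchanged and what followed.

The compounds shown leave open whether the aromatic fluoro of compound 3, which gave a 4.3-fold lower number from compound 2 to compound 3 (0.64 log units; beyond the scatter) on the carbamate, would add anything on top of the oxadiazole, since no pair carries that change with the oxadiazole in place. They also leave open how far the nitrogen tolerates other groups, such as a pyrimidin-2-yl ring or the oxadiazole with a tert-butyl or cyclopropyl in place of its isopropyl.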